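Trimming a Methoxy Group on the Aryl Ketone

The source may report more compounds than this note shows. Statements on the series, on what has been measured and on what is new or still open speak of the compounds shown alone.

Compound 1, `COc1cc(-c2cc(/C=C/C(=O)c3ccc(N)cc3)[nH]n2)cc(OC)c1OC`, gives 86% in a functional assay on HOP-62 cells (Homo sapiens) for cytotoxicity, read by sulforhodamine B assay, with a stated time of 48 h, tested at 1 uM; a lower number here means a stronger effect, a higher number a weaker effect of the compound at the concentration tested. Compound 2, `COc1cc(-c2cc(/C=C/C(=O)c3ccc(Cl)c(Cl)c3)[nH]n2)cc(OC)c1OC`, gives 68% in this assay. Compound 3, `COc1ccc(C(=O)/C=C/c2cc(-c3cc(OC)c(OC)c(OC)c3)n[nH]2)cc1OC`, gives 77% in this assay.

On these three numbers compound 3 stands second highest. Its nearest neighbour is compound 1, and the step of a number 9 percentage points lower from compound 1 to compound 3 (within the scatter) lies within the scatter; the step of a number 9 percentage points higher from compound 2 to compound 3 (within the scatter) is within the scatter as well. Among the compounds with values here, the only step beyond the scatter among the measured compounds is a number 18 percentage points lower from compound 1 to compound 2 (beyond the scatter), a modest one.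

Compound 4, `COc1ccc(C(=O)/C=C/c2cc(-c3cc(OC)c(OC)c(OC)c3)n[nH]2)cc1`, differs from compound 3 in one place: hydrogen in place of methoxy on an aromatic carbon. Within the data shown here, the steps that bear on this change are the two that alter the aryl ring on the carbonyl carbon and end at compound 3, and both stayed within the scatter. A single methoxy group leaving that ring is a smaller alteration than either of those swaps, so the step of a number 1 percentage points higher from compound 3 to compound 4 (within the scatter) is expected to stay within the scatter, with no direction that can be read from the data.

Compound 4 is therefore estimated at 78% in this assay, in a range from 62% to 92%.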

Compound 4, a percentage reported as activity, at one concentration (the size of the read-out at that concentration, not a potency): 87%
The estimate for compound 4 lay 9 percentage points below the measured number, within the range that was stated.
By their numbers in this assay, from the lowest: compounds 2, 3, 1 and 4 (each within the scatter of the next, the first and the last beyond it).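

In this assay, the change from 3,4-dimethoxyphenyl to 4-methoxyphenyl gives a number 10 percentage points higher from compound 3 to compound 4 (within the scatter), so hydrogen can stand in place of this methoxy group, ortho to a methoxy group, without a step beyond the scatter at this single concentration. The 4-methoxyphenyl ketone also provides a second step beyond the scatter, a number 19 percentage points higher from compound 2 to compound 4 (beyond the scatter), which is modest and sets this ring apart from 3,4-dichlorophenyl, while a number 1 percentage points higher from compound 1 to compound 4 (within the scatter) shows that methoxy and amino on that ring cannot be told apart here. No measurement shown explains any of these steps.

Open, from the compounds shown here alone, is whether a hydroxy group, an ethoxy group or a fluorine atom at the place where the methoxy group left would also stay within the scatter of compound 3 and compound 4. Also open, going by these compounds, is whether a single chlorine atom on this ring, rather than the two in compound 2, would be enough to keep a step beyond the scatter from compound 4.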